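The source may hold more compounds than are shown below. What is called first, only, known or untested is meant among the compounds shown, and "the series" means these compounds.

Measured compounds:
compound 1 `COc1ccc(-c2nc(-c3ccc4c(c3)CCN4S(C)(=O)=O)cs2)cc1` with 45400 nM in an assay on isolated protein for inhibition of dual specificity protein phosphatase 3 (Homo sapiens), read by fluorescence, in the presence of a further agent that is not named here; on this read-out lower numbers stand for stronger inhibition and higher numbers for weaker inhibition; compound 2 `COc1ccccc1-c1nc(-c2ccc3c(c2)CCN3S(C)(=O)=O)cs1` with 40200 nM in this assay.

Compound 2 and compound 1 lie within the scatter of each other, as a 1.1-fold lower number from compound 1 to compound 2 (0.05 log units; within the scatter) shows. Compound 3 `Cc1cccc(-c2nc(-c3ccc4c(c3)CCN4S(C)(=O)=O)cs2)c1` carries the change (3-methylphenyl in place of 2-methoxyphenyl on an aromatic carbon). Among the measured compounds shown here, the only measured step, a 1.1-fold lower number from compound 1 to compound 2 (0.05 log units; within the scatter), moved the methoxy group around the phenyl ring without a change beyond the scatter; no measured step removes a methoxy or introduces a methyl. Compound 3 is therefore expected to give a number close to that of compound 2, with a 1.0-fold lower number from compound 2 to compound 3 (0.00 log units; within the scatter) expected to stay within the scatter. The estimate for compound 3 is 40000 nM, in the range 15000 nM to 110000 nM.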

Compound 3, half-maximal inhibitory concentration: 40100 nM
Compound 3: the middle estimate sits 1.0-fold (0.00 log units) below what was measured; the measured number falls inside the stated range.
By their numbers in this assay, from the lowest: compounds 3, 2 and 1 (each within the scatter of the next).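

In this assay, 3-methylphenyl on this aromatic carbon of the five-membered ring stays within the scatter of both methoxyphenyl compounds (a 1.0-fold lower number from compound 2 to compound 3 (0.00 log units; within the scatter); a 1.1-fold lower number from compound 1 to compound 3 (0.05 log units; within the scatter)). The earlier pair both carried a methoxy group, whereas these steps show that, among these compounds, a methoxyphenyl group is not required at this position and that a methyl group serves equally well. No evidence given here accounts for this result.

All three numbers lie within the scatter of each other, so no group shown separates from the others at this position. From the compounds shown here alone, whether an amine or a carboxylic acid on this phenyl ring would move the number beyond the scatter remains open.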